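A few compounds are considered here, and "the series" means these few. Any claim that something is new, unique, unknown or untested is made for them only; others in the source may bear on it.

Working notes on the series. Compound 2 `Cc1cn2c(-c3cn[nH]c3)cnc2c(Nc2cc(Cc3nccs3)ns2)n1`, compound 3 `Cc1cn2c(-c3cn[nH]c3)cnc2c(Nc2cc(Cc3ccccn3)ns2)n1` and compound 1 `Cc1cn2c(-c3cn[nH]c3)cnc2c(Nc2cc(Cn3cccn3)ns2)n1` share one core and differ only in the group carried on the saturated chain carbon bound to an aromatic carbon. In an ADME assay on the whole organism for pharmacokinetics, with Rattus norvegicus as the target, with a stated time of 6 h, at a dose of 10 mg/kg by the oral route (a lower number here means less compound in the circulation, a higher number more compound in the circulation at the dose given), compound 2 gives 1540 ng.h/mL, and compound 3 gives 6880 ng.h/mL. For compound 1 this assay gives "not determined" (no result reported), so no number is reported for it. Compound 2 therefore stands lowest of the two numbers available, with compound 3 the only measured neighbour; the step between them, a 4.5-fold higher number from compound 2 to compound 3 (0.65 log units; beyond the scatter), is the single measured change of this kind in the set.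

Compound 4 `Cc1cn2c(-c3cn[nH]c3)cnc2c(Nc2cc(Cc3ncccc3F)ns2)n1` is not yet measured. Relative to compound 2 the change is 3-fluoropyridin-2-yl in place of 1,3-thiazol-2-yl on a saturated chain carbon bound to an aromatic carbon. The measured step from compound 2 to compound 3 is the one that applies, since it exchanged the same 1,3-thiazol-2-yl at the same place for pyridin-2-yl and was modest but beyond the scatter. Among the compounds with values here, the expectation for compound 4 is a rise of similar size in this assay, upward and beyond the scatter, with no precedent in the set for the added fluorine. Compound 4 is expected to give 5000 ng.h/mL, with a range from 1500 ng.h/mL to 15000 ng.h/mL. The expected step is a 3.2-fold higher number from compound 2 to compound 4 (0.51 log units; beyond the scatter). This estimate is taken to lie close to the measured step from compound 2 to compound 3.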

Compound 4, area under the concentration-time curve: 569 ng.h/mL
Compound 4: the middle estimate sits 8.8-fold (0.94 log units) above what was measured; measured number below the stated range.
By their numbers in this assay, from the lowest: compound 4; then compound 2; then compound 3.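

In this assay, the fluoro in place of hydrogen on an aromatic carbon gives a 12-fold lower number from compound 3 to compound 4 (1.08 log units; beyond the scatter) and is the largest step in the set, so the pyridin-2-yl result does not carry over to the 3-fluoropyridin-2-yl group. Measured against the 1,3-thiazol-2-yl group at the same place, on a saturated chain carbon bound to an aromatic carbon, the new group gives a 2.7-fold lower number from compound 2 to compound 4 (0.43 log units; beyond the scatter) while pyridin-2-yl gave a 4.5-fold higher number from compound 2 to compound 3 (0.65 log units; beyond the scatter), so among these compounds the exchange of ring alone does not set the direction of the step, and a single added fluoro reverses it. Nothing available here accounts for this fall in circulating compound.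

A single oral exposure figure for each compound leaves open which stage between dosing and circulation the fluoro alters. It also leaves open whether the fall is particular to fluoro, which a chloro or a methoxy group in its place on the pyridin-2-yl ring would help to settle.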